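The compounds below may be only part of what the source reports. "The series", "measured", "known", "first", "only" and "open" are said of these compounds alone.

Compound 1 `O=C1ON=C(c2cccs2)/C1=C/c1ccc(O)cc1` gives 4200 nM
Compound 2 `O=C1ON=C(c2cccs2)/C1=C/c1ccccc1` gives 4400 nM
Compound 3 `O=C1ON=C(c2cccs2)/C1=C/c1ccsc1` gives 3000 nM

These three numbers come from a functional assay on the whole organism for inhibition, with Rattus norvegicus as the target (on this read-out lower numbers stand for stronger inhibition and higher numbers for weaker inhibition), and they sit close together. Compound 2 at 4400 nM stands level with the other two, as its gaps to compound 1 and to compound 3 both lie within the usual scatter of repeated measurements.

The next compound to be measured is compound 4 `O=C1ON=C(c2cccs2)/C1=C/c1ccc(F)cc1` which alters compound 2 in one place: fluoro in place of hydrogen on an aromatic carbon and nothing else.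

Within the data shown here, two measured steps bear on this change. The closer one concerns the same aromatic carbon: hydrogen in place of hydroxy gave a 1.0-fold higher number from compound 1 to compound 2 (0.02 log units; within the scatter) and so made no visible difference. The other is a larger change, thiophen-3-yl in place of phenyl, and gave a 1.5-fold lower number from compound 2 to compound 3 (0.17 log units; within the scatter) which also stays within the scatter. Among the measured compounds shown here, no compound with fluoro has been measured yet, and three compounds are a thin basis, but neither step points to a shift in either direction.

No change beyond the scatter is therefore expected, and the estimate is a 1.1-fold lower number from compound 2 to compound 4 (0.04 log units; within the scatter) for this step. For compound 4 the estimated value is 4000 nM with an expected range from 2000 nM to 8000 nM on this read-out.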

Compound 4, half-maximal inhibitory concentration: 4800 nM
The estimate for compound 4 lay 1.2-fold (0.08 log units) below the measured number, within the range that was stated.
By their numbers in this assay, from the lowest: compounds 3, 1, 2 and 4 (each within the scatter of the next).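

In this assay, fluoro in place of hydrogen on this aromatic carbon, para to a large group, gives a 1.1-fold higher number from compound 2 to compound 4 (0.04 log units; within the scatter), and fluoro in place of hydroxy on the same carbon gives a 1.1-fold higher number from compound 1 to compound 4 (0.06 log units; within the scatter). Among these compounds, the earlier compounds compared only two groups at this position, whereas compounds 1, 2 and 4 now show that hydrogen, hydroxy and fluoro all stand level here, with none of the three going against that reading. No measurement is available that could explain why these swaps leave the number in place.

Going by these compounds, all three groups at this carbon are small, so it remains open whether a carboxylic acid, an amine or a longer chain in the same place would move the number beyond the scatter. It is also open whether fluoro would behave the same way on another carbon of the ring, or on the thiophen-3-yl ring of compound 3, since the compounds shown test only this single position with this group.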